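The compounds below may be only part of what the source reports. "The series", "measured", "known", "first", "only" and "open" are said of these compounds alone.

Compound 1 `CON(C)C(=O)[C@H]1CC2=C(CCCC2(C)C)C[C@@H]1c1ccccc1` gives > 23000 nM in an assay on isolated protein for inhibition of Apoptosis regulator Bcl-2 (Homo sapiens), read by fluorescence polarization, with stated times of 5 min and 10 min (on this read-out lower numbers stand for stronger inhibition and higher numbers for weaker inhibition), which is a limit of the assay. Compound 2 `CC(C)=CCCC1=CC[C@H](C(=O)Nc2ccc(O)cc2)[C@@H](c2ccccc2)C1` gives > 23000 nM in this assay, again a limit. Compound 3 `CC(C)=CCCC1=CC[C@@H](C(=O)Nc2ccc(O)cc2)[C@H](c2ccccc2)C1` gives > 23000 nM in this assay, also a limit.

Compound 2 therefore stands nowhere on a number: all three measured values are limits (the limit of > 23000 nM in this assay, at which 3 of the 3 values shown sit). For the measured compounds named here, the only measured step, a step that the two limits leave unreadable from compound 2 to compound 3, cannot be read for the same reason, although the two compounds differ only in configuration (the fact that compounds 2 and 3 differ only in the configuration as drawn). Compound 4 `COc1ccc(NC(=O)[C@H]2CC=C(CCC=C(C)C)C[C@@H]2c2ccccc2)cc1` differs from compound 2 by methyl in place of hydrogen on an oxygen on an aromatic ring. Going by the values given here, no measured step bears on a change of this kind, so no direction can be drawn from the data. Compound 4 is expected to remain at the limit, with a step that the limit leaves unreadable from compound 2 to compound 4 as the estimated step. The estimate for compound 4 is 30000 nM, ranging from 10000 nM to 100000 nM.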

Compound 4, inhibition constant: > 23000 nM
Compound 4 was reported as a limit (the forecaster's own chance of this, stated with the estimate: 85%); the middle value lies beyond the limit too.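

For the compounds shown here, compound 2 and compound 4 are both reported only as limits, so no step between them can be read. The compounds shown leave open whether methyl in place of hydrogen on that oxygen changes inhibition at all.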